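The source may hold more compounds than are shown below. What is called first, only, known or untested is meant among the compounds shown, and "the series" means these compounds.

Series notes. Compound 1 `c1ccc(N2CCN(CCCCCOc3ccc4c(c3)CCC4)CC2)cc1`, compound 2 `Clc1cccc(N2CCN(CCCCOc3ccc4c(c3)CCC4)CC2)c1` and compound 3 `FC(F)(F)c1cccc(N2CCN(CCCCCOc3ccc4c(c3)CCC4)CC2)c1` have been run in a functional assay on the whole organism for inhibition, with Mus musculus as the target, at a dose of 25 mg/kg by the oral route; a lower number here means less inhibition, a higher number more inhibition at the dose given (going by the name of the read-out). Compound 2 gives 37%, the highest of the three numbers, although the gaps to compound 3 at 33% and to compound 1 at 27% both lie within the scatter. Going by the values given here, the only single-point step measured, a number 6 percentage points higher from compound 1 to compound 3 (within the scatter), concerns a trifluoromethyl on an aromatic carbon and is within the scatter.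

Compound 4 `O=[N+]([O-])c1ccc(N2CCN(CCCCOc3ccc4c(c3)CCC4)CC2)cc1` differs from compound 2 by 4-nitrophenyl in place of 3-chlorophenyl on an amine nitrogen in a ring. Among the compounds with values here, no measured step changes the aryl group on the ring nitrogen, so nothing here bears directly on this change; the one step known is flat. The step in this assay is therefore expected to be a number 2 percentage points lower from compound 2 to compound 4 (within the scatter), nothing beyond the scatter. Compound 4 is estimated at 35%, range 20% to 50%.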

Compound 4, a percentage reported as inhibition, in the whole organism at one dose (the size of the read-out at that dose, not a potency): 0%
Estimate against measurement, compound 4: 35 percentage points above; the whole stated range lies above it.
By their numbers in this assay, from the lowest: compound 4; then compounds 1, 3 and 2 (each within the scatter of the next).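

In this assay, going by these compounds alone, the aryl group on the ring nitrogen is not a neutral position: a number 37 percentage points lower from compound 2 to compound 4 (beyond the scatter) with 4-nitrophenyl in place of 3-chlorophenyl, the first step beyond the scatter. Compounds 1, 2 and 3 lie within the scatter of one another and gave no sign of this. Nothing available gives a reason for the loss.

As far as these compounds go, whether the drop goes with the nitro group itself or with where it sits on the phenyl ring stays open. A nitrile or an amine in place of the nitro group would help separate the two.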